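The compounds below may be only part of what the source reports. "The series", "measured", "known", "first", "only" and "open" are said of these compounds alone.

Compound 1 `C/N=C(\S)CCn1nc(-c2ccccc2)ccc1=O` and compound 2 `C/N=C(\S)CCn1ncccc1=O` share one core, and in a functional assay on the whole organism (stomach) for inhibition, with Rattus norvegicus as the target, at a dose of 100 mg/kg by the intraduodenal route (a lower number here means less inhibition, a higher number more inhibition at the dose given (going by the name of the read-out)), compound 1 gives 68.2% while compound 2 gives 35.7%. The change between them is hydrogen in place of phenyl on an aromatic carbon and the step it made is a number 32.5 percentage points lower from compound 1 to compound 2 (beyond the scatter). Compound 3 `N=C(S)CCn1nc(-c2ccccc2)c2ccccc2c1=O` is built on a different core; how that core differs from the core of compound 1 is not broken down here. In this assay compound 3 gives 73.3%, which lies within the scatter of the number for compound 1. Compound 4 `N=C(S)CCn1ncc2ccccc2c1=O` has not yet been measured. It differs from compound 3 by hydrogen in place of phenyl on an aromatic carbon, the same kind of change as from compound 1 to compound 2; here, though, the aromatic carbon that loses the phenyl sits in a fused or bridged system of two rings, ortho to a fused ring and meta to a group of 5 heavy atoms, rather than meta to a group of 6 heavy atoms. For the measured compounds named here, because the one measured example of this change gave a number 32.5 percentage points lower from compound 1 to compound 2 (beyond the scatter), a step of about that size is expected for compound 4, a number 32.3 percentage points lower from compound 3 to compound 4 (beyond the scatter). Compound 4 is therefore estimated to give 41% in this assay, plausibly between 22% and 58%.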

Compound 4, a percentage reported as inhibition, in the whole organism at one dose (the size of the read-out at that dose, not a potency): 58.3%
Estimate against measurement, compound 4: 17.3 percentage points below; the whole stated range lies below it.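

In this assay, hydrogen in place of phenyl on an aromatic carbon lowered the number on both cores, but the earlier size did not carry over, the new step being a number 15 percentage points lower from compound 3 to compound 4 (beyond the scatter). Set side by side, the two steps differ: the same change on two cores in this assay, a number 32.5 percentage points lower (beyond the scatter) from compound 1 to compound 2 and a number 15 percentage points lower (beyond the scatter) from compound 3 to compound 4, 17.5 percentage points apart, beyond the scatter of two such steps. This shows that the direction of the change was the same in both pairs while its size was not, so a step measured on one core gave only its direction on the other; with two pairs, it does not show what in the cores goes with the difference in size, nor what the step would be on any further core.

The compounds shown leave open what a methyl group or a methoxy group would give in place of the phenyl, on either core. They also leave open how a longer chain, or a carboxylic acid at the end of the chain, would alter the number.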